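Difluorophenyl isomer exchange on the amide nitrogen

This account rests on a few compounds, and the source may have more. Where it says the series, first, only, none or still open, it means among the compounds named here.

In an ADME assay on LLC-MK2 cells (Macaca mulatta) for cytotoxicity, read by spectrophotometry and crystal violet staining, with a stated time of 4 days (on this read-out lower numbers stand for higher toxicity in this test and higher numbers for lower toxicity in this test), compound 2 (`CC(C)n1ncc2c(C(=O)Nc3cc(F)ccc3F)cc(-c3cccs3)nc21`) gives 100000 nM and compound 1 (`CC(C)n1ncc2c(C(=O)N3CCc4cccnc43)cc(-c3cccs3)nc21`) gives 50000 nM, and these two values lie within the scatter of each other. Compound 3 (`CC(C)n1ncc2c(C(=O)Nc3cccc(F)c3F)cc(-c3cccs3)nc21`) differs from compound 2 as follows: 2,3-difluorophenyl in place of 2,5-difluorophenyl on an amide-type nitrogen. In words, 2,3-difluorophenyl stands in place of 2,5-difluorophenyl on an amide-type nitrogen. Among the compounds with values here, the only measured step, a 2.0-fold higher number from compound 1 to compound 2 (0.30 log units; within the scatter), is a larger exchange on the carbonyl carbon and stays within the scatter. No step beyond the scatter is therefore expected in this assay. The estimated step is a 1.3-fold lower number from compound 2 to compound 3 (0.10 log units; within the scatter). Compound 3 is expected at 80000 nM, with an estimated range of 40000 nM to 160000 nM.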

Compound 3, half-maximal cytotoxic concentration: 75000 nM
Estimate against measurement, compound 3: 1.1-fold (0.03 log units) above; measured number inside the range.
By their numbers in this assay, from the lowest: compounds 1, 3 and 2 (each within the scatter of the next).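

Exchanging 2,5-difluorophenyl for 2,3-difluorophenyl on the amide-type nitrogen stays within the scatter in this assay (a 1.3-fold lower number from compound 2 to compound 3 (0.12 log units; within the scatter)), so this isomer change does not separate the two compounds on this read-out. The larger exchange on the carbonyl carbon also stays within the scatter with the new group in place (a 1.5-fold higher number from compound 1 to compound 3 (0.18 log units; within the scatter)). No measurement shown here accounts for these results. Open, as far as these compounds go, is whether a carboxylic acid or an amine on the aromatic ring of the amide group would give a step beyond the scatter in this assay.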